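Side-chain swap on the compound 2 scaffold

This account rests on a few compounds, and the source may have more. Where it says the series, first, only, none or still open, it means among the compounds named here.

compound 1 `CC1(C)CCC[C@]2(C)[C@@H](/C=C/C3=CCOC3=O)C(C=O)=CC(=O)[C@@H]12` gives 45900 nM
compound 2 `CC1=CC(=O)[C@H]2C(C)(C)CCC[C@]2(C)[C@H]1/C=C/c1ccoc1` gives 14000 nM

In a functional assay on A549 cells (Homo sapiens) for inhibition, read by sulforhodamine B assay (on this read-out lower numbers stand for higher toxicity in this test and higher numbers for lower toxicity in this test), compound 2 holds the lower of the two numbers, and the gap to compound 1 lies beyond the scatter. Compound 3 `CC1=CC(=O)[C@H]2C(C)(C)CCC[C@]2(C)[C@H]1/C=C/C1=CCOC1=O` keeps the core of compound 2 and changes the side chain by a group of 6 heavy atoms (4 carbon, 2 oxygen; one five-membered non-aromatic ring with 1 hetero atom) in place of a group of 5 heavy atoms (4 carbon, 1 oxygen; one five-membered aromatic ring with 1 hetero atom), on a double-bonded chain carbon bound to a double-bonded chain carbon, on a double-bonded chain carbon bound to a double-bonded chain carbon. Within the data shown here, no measured step isolates this change. A modest rise in this assay is expected because compound 1, which carries the same entering group, gives 45900 nM, though its core differs. The expected size is a 1.6-fold higher number from compound 2 to compound 3 (0.20 log units; within the scatter), close to the scatter. For compound 3 the estimate is 22000 nM, with an expected range of 8000 nM to 55000 nM.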

Compound 3, concentration lethal to 50% of the cells: 39600 nM
Estimate against measurement, compound 3: 1.8-fold (0.26 log units) below; the range from low to high includes it.
By their numbers in this assay, from the lowest: compound 2; then compounds 3 and 1 (each within the scatter of the next).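

In this assay, the side chain at this place matters on the methyl-bearing core: the non-aromatic five-membered ring in place of furan-3-yl gives a 2.8-fold higher number from compound 2 to compound 3 (0.45 log units; beyond the scatter) on this read-out. Methyl in place of formyl on a double-bonded ring carbon gives a 1.2-fold lower number from compound 1 to compound 3 (0.06 log units; within the scatter) with this side chain in place, so that pair stays unseparated. Nothing available explains the side-chain step. Still open, as far as these compounds go, is how an amine or a carboxylic acid in place of furan-3-yl would read, and whether formyl would matter alongside furan-3-yl.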